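The compounds below may be only part of what the source reports. "The series", "measured", "known", "first", "only" and "open" are said of these compounds alone.

Compound 1 `Cc1c(CN2CCCC2)cc(-c2ccc(F)cc2)n1Nc1ccnc2cc(Cl)ccc12`: 4.86
Compound 2 `Cc1ccc(-c2cc(CN3CCCC3)c(C)n2Nc2ccnc3cc(Cl)ccc23)cc1`: 5.19

Among the compounds with values here, in a physicochemical assay for lipophilicity, measured as octanol-water partition (on this read-out higher numbers stand for higher lipophilicity and lower numbers for lower lipophilicity), compound 2 stands highest of the two numbers measured so far; the nearest is compound 1, separated from it by the step of a number 0.33 log units higher from compound 1 to compound 2 (beyond the scatter). Compound 3 `Cc1c(CN2CCCC2)cc(-c2ccc(N)cc2)n1Nc1ccnc2cc(Cl)ccc12` differs from compound 2 by amino in place of methyl on an aromatic carbon, para to a large group. Within the data shown here, the single measured step, a number 0.33 log units higher from compound 1 to compound 2 (beyond the scatter), bears on this only loosely: it swapped one group at the same aromatic carbon, but neither of the measured compounds carries an amino group. The incoming group brings a hydrogen-bond donor and acceptor where the leaving methyl brings neither. Among the measured compounds shown here, a move downward in this assay is expected, of a size well beyond the one measured step. For compound 3 the estimate is 3.4, in the range 2.8 to 4. That estimate means an expected step of a number 1.79 log units lower from compound 2 to compound 3 (beyond the scatter).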

Compound 3, partition coefficient: 4.38
Compound 3: middle estimate off by 0.98 log units, on the low side, outside the stated range (above it).
By their numbers in this assay, from the lowest: compound 3; then compound 1; then compound 2.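

In this assay, the aromatic carbon para to a large group now carries a third group, and amino gives the lowest number of the series. Amino in place of methyl gives a number 0.81 log units lower from compound 2 to compound 3 (beyond the scatter), while amino in place of fluoro gives a number 0.48 log units lower from compound 1 to compound 3 (beyond the scatter), so the position responds to more than the swap between methyl and fluoro, and the new group falls below both earlier ones. Nothing shown accounts for the size of these steps.

The compounds shown leave open where a hydroxyl, a carboxylic acid or an acetylated amine at this same carbon would fall relative to compound 3. They also leave open whether amino in place of methyl would give a step of similar size elsewhere on the shared core.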